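A few compounds are considered here, and "the series" means these few. Any claim that something is new, unique, unknown or untested is made for them only; others in the source may bear on it.

Measured compounds:
- compound 1 `COCCCOc1cc(C)c(-c2cccc(COc3ccc(OCC(=O)O)c(F)c3)c2)c(C)c1`: "not determined" (no result reported)
- compound 2 `CCOc1cc(C)c(-c2cccc(COc3ccc(OCC(=O)O)c(F)c3)c2)c(C)c1`: 65.9 nM
- compound 3 `CCCCOc1cc(C)c(-c2cccc(COc3ccc(OCC(=O)O)c(F)c3)c2)c(C)c1`: "not determined" (no result reported)

The series shares one core and varies only the ether chain on the outer ring. Among the measured compounds shown here, in a functional assay on CHO cells for agonist activity at Free fatty acid receptor 1 (Homo sapiens), read by FLIPR and calcium flux (on this read-out higher numbers stand for an effect only at larger amounts of compound and lower numbers for an effect already at smaller amounts), compound 2 gives 65.9 nM, the only number available in the set. For the measured compounds named here, compound 1 stands without a number, as does compound 3, so no step between measured compounds can be drawn and nothing is known of how the chain length or its terminal group moves the read-out.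

Compound 4 `CCCOc1cc(C)c(-c2cccc(COc3ccc(OCC(=O)O)c(F)c3)c2)c(C)c1` differs from compound 1 by hydrogen in place of methoxy on a saturated chain carbon, three bonds along the chain from an oxygen on an aromatic ring. In this assay, going by the values given here, no step is available to size this change; the expectation is that the change will stay within the scatter or at most give a small shift in either direction, with compound 2 as the nearest anchor through 65.9 nM.

Compound 4 is therefore expected to give about 55 nM, with a range from 15 nM to 200 nM.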

Compound 4, half-maximal effective concentration: 106 nM
For compound 4 the middle estimate is 1.9-fold (0.28 log units) below the measured one; the measured number falls inside the stated range.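

In this assay the series now has its first readable step: methyl in place of hydrogen on a saturated chain carbon, two bonds along the chain from an oxygen on an aromatic ring, gives a 1.6-fold higher number from compound 2 to compound 4 (0.21 log units; within the scatter). Among the compounds shown here, at this position, then, the added methyl leaves the read-out within what repeated measurements would scatter, which the single value of compound 2 could not show. No measurement at hand bears on the reason for this result.

Steps involving compound 1 or compound 3 cannot be read, so the effect of the methoxy group at the end of the 3-methoxypropyl chain remains unsized. Also open, as far as these compounds go, is whether a pentyl chain, or a propyl chain ending in an amine or a carboxylic acid, would stay this close to compound 2.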